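Working notes on piperazine aryl swap in the series

This account rests on a few compounds, and the source may have more. Where it says the series, first, only, none or still open, it means among the compounds named here.

For the measured compounds named here, compound 2 `COc1ccc(/C=C2\NC(=O)N(CCCCN3CCN(c4cccc(Cl)c4Cl)CC3)C2=O)cc1OC1CCCC1` gives the lower of the two numbers so far: in an assay on CHO cells for displacement of a labelled ligand from 5-hydroxytryptamine receptor 7 (Homo sapiens), read by scintillation counting, with a stated time of 60 min (on this read-out higher numbers stand for weaker inhibition and lower numbers for stronger inhibition), compound 2 gives 125 nM. Compound 1 `COc1ccc(/C=C2\NC(=O)N(CCCCN3CCN(c4ncccn4)CC3)C2=O)cc1OC`, which carries a different group on the piperazine nitrogen and a different ether on the benzylidene ring, gives 933 nM in this assay. Going by the values given here, these two compounds differ in two places at once, so the figures show only that compound 1 sits higher than compound 2, beyond the scatter, and do not tell which of the two changes carries the gap.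

Compound 3 `COc1ccc(/C=C2\NC(=O)N(CCCCN3CCN(c4ncccn4)CC3)C2=O)cc1OC1CCCC1` is not yet measured. It keeps the cyclopentyl ether of compound 2 and differs from it in one place: pyrimidin-2-yl in place of 2,3-dichlorophenyl on an amine nitrogen in a ring.

The expectation for this step is a rise in the number, that is weaker inhibition, of a size clearly beyond the scatter but not as large as the full gap between compound 1 and compound 2, since only one of the two differences is undone. The estimated step from compound 2 to compound 3 is a 3.2-fold higher number from compound 2 to compound 3 (0.51 log units; beyond the scatter). Compound 3 is therefore expected to give about 400 nM in this assay, with a plausible range from 150 nM to 1200 nM.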

Compound 3, inhibition constant: 298 nM
Compound 3: middle estimate off by 1.3-fold (0.13 log units), on the high side, and the stated range covers the measured number.
By their numbers in this assay, from the lowest: compound 2; then compound 3; then compound 1.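

Compound 3 resolves the earlier two-place comparison into two single-place steps, so each change can now be read on its own. On an amine nitrogen in a ring, with the cyclopentyl ether held fixed, pyrimidin-2-yl in place of 2,3-dichlorophenyl gives a 2.4-fold higher number from compound 2 to compound 3 (0.38 log units; beyond the scatter) in this assay and so accounts for only part of the earlier difference. With pyrimidin-2-yl held fixed, cyclopentyl in place of methyl on an oxygen on an aromatic ring gives a 3.1-fold lower number from compound 1 to compound 3 (0.50 log units; beyond the scatter) in this assay, showing that the ether also matters at this position and that neither change alone carries the full difference. Nothing available explains either step.

Whether the ether step keeps its size with 2,3-dichlorophenyl on the amine nitrogen remains open, since both steps are known only with the partner groups shown here. Also open, on these data alone, is how a plain phenyl or a pyridin-2-yl on that nitrogen, or an ethyl or a cyclohexyl on the oxygen, would compare with these three compounds.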